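Methoxy for Methyl in a Pyrazoline Series

A few compounds are considered here, and "the series" means these few. Any claim that something is new, unique, unknown or untested is made for them only; others in the source may bear on it.

Compound 1 `CCC(=O)N1N=C(c2ccc(OC)cc2)CC1c1ccc(Cl)cc1` and compound 2 `CCC(=O)N1N=C(c2ccc(OC)cc2)CC1c1ccc(C)cc1` share one core and differ only in the group on the outer phenyl ring. In an assay on isolated protein for inhibition of Amine oxidase [flavin-containing] B (Bos taurus) (on this read-out lower numbers stand for stronger inhibition and higher numbers for weaker inhibition), compound 1 gives 851 nM, and compound 2 gives 10000 nM, the higher of the two numbers on record; the step of a 12-fold higher number from compound 1 to compound 2 (1.07 log units; beyond the scatter) separates them. Compound 3 `CCC(=O)N1N=C(c2ccc(OC)cc2)CC1c1ccc(OC)cc1` is not yet measured. It differs from compound 2 by the change (methoxy in place of methyl on an aromatic carbon), at a site on the outer ring para to a large group; cut one bond further out, the change reads 4-methylphenyl to 4-methoxyphenyl. Among the compounds with values here, the only measured step concerns chloro against methyl, not methyl against methoxy, so no step in this set bears directly on the change; it shows only that the group at this position can move the number a long way. Without a direct precedent, the expected step of a 1.3-fold lower number from compound 2 to compound 3 (0.10 log units; within the scatter) is small, and compound 3 is estimated in this assay at 8000 nM, within 2500 nM to 30000 nM.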

Compound 3, half-maximal inhibitory concentration: 2400 nM
For compound 3 the middle estimate is 3.3-fold (0.52 log units) above the measured one; the whole stated range lies above it.
By their numbers in this assay, from the lowest: compound 1; then compound 3; then compound 2.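

Replacing methyl with methoxy gives a 4.2-fold lower number from compound 2 to compound 3 (0.62 log units; beyond the scatter) in this assay and so shows that this position responds to more than the exchange of chloro and methyl. Methoxy does not match chloro, however: the change between them is a 2.8-fold higher number from compound 1 to compound 3 (0.45 log units; beyond the scatter) and places methoxy between the other two groups, with chloro giving the lowest number and methyl the highest, each gap lying beyond the usual scatter. Nothing available here accounts for this order or connects it to any feature of the three groups.

With only chloro, methoxy and methyl on record at this place, the compounds shown leave open whether any other group would give a number lower than that of chloro, or whether a fluoro group, a bromo group or an amine would fit the same order. They also leave open how a longer chain such as ethoxy would compare with methoxy on the outer phenyl ring, and whether the same order would hold if the propionyl group or the 4-methoxyphenyl group on the shared core were replaced.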